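Fluoro placement on the aryl urea: rice whole-organism read-out

The compounds below may be only part of what the source reports. "The series", "measured", "known", "first", "only" and "open" are said of these compounds alone.

For the measured compounds named here, compound 2 `C[C@@H](NC(=O)Nc1cccc(C(F)(F)F)c1)c1ccccc1` stands lowest of the three numbers so far in an ADME assay on the whole organism with Oryza sativa as the target, tested at 0.1 uM; on this read-out higher numbers stand for a weaker effect at the one concentration tested and lower numbers for a stronger effect; in it compound 2 gives 82%. Compound 1 `Cc1cccc(NC(=O)N[C@H](C)c2ccccc2)c1` carries methyl where compound 2 carries trifluoromethyl, and in this assay compound 1 gives 100%; the step is a number 18 percentage points lower from compound 1 to compound 2 (beyond the scatter). Compound 3 `C[C@@H](NC(=O)Nc1cccc(C(F)(F)F)c1F)c1ccccc1` adds fluoro to the ring of compound 2, and in this assay compound 3 gives 99%; the step is a number 17 percentage points higher from compound 2 to compound 3 (beyond the scatter).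

Compound 4 `C[C@@H](NC(=O)Nc1cc(C(F)(F)F)ccc1F)c1ccccc1` is not yet measured. It differs from compound 2 by fluoro in place of hydrogen on an aromatic carbon, the fluoro sitting on an aromatic carbon ortho to a large group and para to a trifluoromethyl group, so not at the same place as the fluoro of compound 3. Going by the values given here, the only step that bears on it is the fluoro addition from compound 2 to compound 3, which raised the number by a modest amount beyond the scatter. A step of similar direction is therefore expected, though the different place leaves the size open. For compound 4 the expected step is a number 10 percentage points higher from compound 2 to compound 4 (within the scatter). Compound 4 is estimated at 92% in this assay, within a range from 78% to 100%.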

Compound 4, a percentage reported as activity, at one concentration (the size of the read-out at that concentration, not a potency): 87%
The estimate for compound 4 lay 5 percentage points above the measured number; the measured number falls inside the stated range.
By their numbers in this assay, from the lowest: compounds 2 and 4 (each within the scatter of the next); then compounds 3 and 1 (each within the scatter of the next).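

In this assay the exchange of hydrogen for fluoro on an aromatic carbon ortho to a large group and para to a trifluoromethyl group amounts to a number 5 percentage points higher from compound 2 to compound 4 (within the scatter) and so cannot be told apart from no change at this place. The same exchange at the other fluoro place in the series amounts to a number 17 percentage points higher from compound 2 to compound 3 (beyond the scatter) and thus shows that, across these two fluoro compounds, the size of the read-out step goes with where the fluoro sits and not with the exchange of hydrogen for fluoro as such. No measurement on hand accounts for the difference between the two places.

The compounds shown leave open whether this place tolerates anything larger than fluoro, such as chloro, methoxy or an amine, or whether the flat step holds only for the smallest exchange. They also leave open whether the same fluoro at this place would give a similar step with methyl in place of the trifluoromethyl group, as in the core of compound 1.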